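The source may hold more compounds than are shown below. What is called first, only, known or untested is meant among the compounds shown, and "the series" means these compounds.

Compounds measured so far:
compound 1 `O=C(Nc1cccc(-c2oc3cc(-c4ccc(F)cc4)ccc3c(=O)c2O)c1)c1ccc(Cl)cc1`, 4730 nM
compound 2 `Cc1cc(C(=O)Nc2cccc(-c3oc4cc(-c5ccc(F)cc5)ccc4c(=O)c3O)c2)ccc1F`, 7710 nM

In a functional assay on MCF7 cells (Homo sapiens) for antiproliferative activity, read by CCK-8 assay, with a stated time of 72 h (on this read-out higher numbers stand for weaker inhibition and lower numbers for stronger inhibition), compound 1 gives 4730 nM, the lowest of the two numbers, with compound 2 close by: a 1.6-fold higher number from compound 1 to compound 2 (0.21 log units; within the scatter). Compound 3 `O=C(Nc1cccc(-c2oc3cc(-c4ccc(F)cc4)ccc3c(=O)c2O)c1)c1ccc(-c2ccccc2)cc1` differs from compound 1 by phenyl in place of chloro on an aromatic carbon. Among the compounds with values here, no measured step covers this change; the only step known, a 1.6-fold higher number from compound 1 to compound 2 (0.21 log units; within the scatter), concerns another group on the same carbonyl carbon and stayed within the scatter. The step from compound 1 to compound 3 in this assay is therefore expected to be small, with no firm direction, a 1.1-fold higher number from compound 1 to compound 3 (0.02 log units; within the scatter). Compound 3 is estimated at 5000 nM, within 1500 nM to 16000 nM.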

Compound 3, half-maximal inhibitory concentration: 38500 nM
Compound 3: the middle estimate sits 7.7-fold (0.89 log units) below what was measured; the whole stated range lies below it.
By their numbers in this assay, from the lowest: compounds 1 and 2 (each within the scatter of the next); then compound 3.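

Within the data shown here, putting phenyl in place of chloro on this aromatic carbon, para to a large group, gives the first step here beyond the scatter, an 8.1-fold higher number from compound 1 to compound 3 (0.91 log units; beyond the scatter), in this assay. The comparison with the other measured group points the same way, a 5.0-fold higher number from compound 2 to compound 3 (0.70 log units; beyond the scatter), so 4-phenylphenyl gives weaker inhibition than either 4-chlorophenyl or 4-fluoro-3-methylphenyl on this carbonyl carbon. Nothing at hand accounts for this loss. On these data alone, whether a methoxy, an amine or a carboxylic acid on this carbon would keep the number near that of compound 1 stays open.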